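The source may hold more compounds than are shown below. What is called first, only, known or untested is meant among the compounds shown, and "the series" means these compounds.

In a functional assay on KB cells (Homo sapiens) for cytotoxicity, read by colorimetric assay (a higher number here means a weaker inhibitor, a lower number a stronger inhibitor), compound 1 `COc1cc([C@@H]2CCc3cc(O)c(OC)cc3O2)ccc1O` reads 69000 nM and compound 2 `COc1ccc2c(c1)O[C@H](c1ccc(O)c(OC)c1)CC2` reads 97900 nM with the two lying within the usual scatter of each other, so neither can be ranked ahead of the other. Compound 3 `COc1cc2c(cc1O)CC[C@@H](c1ccc(O)c(O)c1)O2` is still unmeasured. It differs from compound 1 by hydrogen in place of methyl on an oxygen on an aromatic ring in one place: hydrogen in place of methyl on an oxygen on an aromatic ring, or methoxy to hydroxy. For the measured compounds named here, the only measured step, a 1.4-fold higher number from compound 1 to compound 2 (0.15 log units; within the scatter) for hydrogen in place of hydroxy on an aromatic carbon, is a different change that stays within the scatter. It is therefore only a loose guide, and no step beyond the scatter is expected in this assay in either direction. The expected change is a 1.4-fold lower number from compound 1 to compound 3 (0.14 log units; within the scatter) and so remains small. Compound 3 is estimated at 50000 nM with an expected range of 20000 nM to 110000 nM in this measurement.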

Compound 3, half-maximal inhibitory concentration: 24600 nM
Compound 3: middle estimate off by 2.0-fold (0.31 log units), on the high side; low and high end bracket the measured number.
By their numbers in this assay, from the lowest: compound 3; then compounds 1 and 2 (each within the scatter of the next).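

In this assay, for the compounds shown here, the change from methoxy to hydroxy gives a 2.8-fold lower number from compound 1 to compound 3 (0.45 log units; beyond the scatter) and is the first step here to lie beyond the usual scatter. The earlier step, a 1.4-fold higher number from compound 1 to compound 2 (0.15 log units; within the scatter), changed a different place and stayed within the scatter, so the oxygen on an aromatic ring is the first place shown to respond, if only modestly, to a small edit: one methyl leaves and a hydrogen enters. Nothing available explains why the number falls.

This step rests on a single pair of compounds, so it sets no general rule for the series. On these data alone, whether an ethoxy group or a longer chain on this oxygen, or an amine in its place, would move the number further remains open, as does the effect of the same change at the other methoxy group.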